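The source may hold more compounds than are shown below. What is called first, only, known or untested is meant among the compounds shown, and "the series" means these compounds.

The measured compounds in a functional assay on SH-SY5Y cells (Homo sapiens) for cytotoxicity, read by MTT assay, with stated times of 8 h, 30 min and 12 h, tested at 5 uM; a higher number here means a stronger effect of the compound at the concentration tested, a lower number a weaker effect:

Compound 1 `N=C(NCc1ccccc1)[C@@H]1CCC(=O)N1Cc1ccccc1`, 20.7%.
Compound 2 `N=C(NCc1ccc(O)cc1)[C@@H]1CCC(=O)N1Cc1ccccc1`, 37.6%.
Compound 3 `Cc1ccc(CN2C(=O)CC[C@H]2C(=N)NCc2ccccc2)cc1`, 24.8%.

Compound 2 differs from compound 1 by hydroxy in place of hydrogen on an aromatic carbon, and this change gave a number 16.9 percentage points higher from compound 1 to compound 2 (beyond the scatter). Compound 3 differs from compound 1 by methyl in place of hydrogen on an aromatic carbon, a step of a number 4.1 percentage points higher from compound 1 to compound 3 (within the scatter). Compound 3 thus stands close to compound 1 in this assay and beyond the scatter from compound 2.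

Compound 4 `Cc1ccc(CN2C(=O)CC[C@H]2C(=N)NCc2ccc(O)cc2)cc1` has not yet been measured in this assay. It differs from compound 3 by hydroxy in place of hydrogen on an aromatic carbon. Among the compounds with values here, this is the same change as the one from compound 1 to compound 2, made here on the core of compound 3 rather than the core of compound 1; the place of the change is described in identical words in both cases, so it is the same change and not merely the same kind. Among the compounds shown it occurs twice in all.

Compound 4 is expected to show a step of a number 15.2 percentage points higher from compound 3 to compound 4 (beyond the scatter). Within the data shown here, that expectation rests on the earlier step of a number 16.9 percentage points higher from compound 1 to compound 2 (beyond the scatter), the only prior instance of this change. Compound 4 is therefore estimated at 40%, between 28% and 52%.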

Compound 4, a percentage reported as activity, at one concentration (the size of the read-out at that concentration, not a potency): 23.8%
For compound 4 the middle estimate is 16.2 percentage points above the measured one; the measured number lies below the stated range.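

In this assay, hydroxy in place of hydrogen on an aromatic carbon gave a number 1 percentage points lower from compound 3 to compound 4 (within the scatter), so the step seen on the core of compound 1 did not carry over to the core of compound 3: the same change on two cores in this assay, a number 16.9 percentage points higher (beyond the scatter) from compound 1 to compound 2 and a number 1 percentage points lower (within the scatter) from compound 3 to compound 4, 17.9 percentage points apart, beyond the scatter of two such steps. Read the other way, methyl in place of hydrogen on an aromatic carbon gave a number 13.8 percentage points lower from compound 2 to compound 4 (beyond the scatter), which also departs from the step made without the hydroxy group: the same change on two cores in this assay, a number 4.1 percentage points higher (within the scatter) from compound 1 to compound 3 and a number 13.8 percentage points lower (beyond the scatter) from compound 2 to compound 4, 17.9 percentage points apart, beyond the scatter of two such steps. Together these show that the two changes do not simply add in these compounds, but this single set of four compounds does not explain the mismatch or show how either change would behave on any other core.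

The compounds shown leave open whether a methoxy group or an amine in place of the hydroxy would follow compound 2 or compound 4. They also leave open whether a chlorine atom or a longer chain in place of the methyl would cancel the hydroxy step as compound 4 does.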